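This account rests on a few compounds, and the source may have more. Where it says the series, first, only, none or still open, it means among the compounds named here.

Working notes on the series. In a functional assay on MDA-MB-231 cells (Homo sapiens) for antiproliferative activity, with a stated time of 72 h (a higher number here means a weaker inhibitor, a lower number a stronger inhibitor), compound 1 `Cn1c(N2N=C(c3ccccc3)CC2c2ccc(F)cc2)nc(-c2ccccc2)c(C#N)c1=O` gives 11800 nM. Compound 2 `Cn1c(N2N=C(c3ccccc3)CC2c2ccc(Cl)cc2)nc(-c2ccc(Cl)cc2)c(C#N)c1=O` gives 25100 nM in this assay, the highest of the two numbers recorded so far; the nearest is compound 1, whose number is lower by a margin beyond the usual scatter. For the measured compounds named here, no pair of measured compounds differs in one place only, so no single step has been measured directly.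

Compound 3 `Cn1c(N2N=C(c3ccccc3)CC2c2ccc(F)cc2)nc(-c2ccc(Cl)cc2)c(C#N)c1=O` is not yet measured. It differs from compound 2 by fluoro in place of chloro on an aromatic carbon, on an aromatic carbon of a six-membered aromatic ring of carbon only, para to a large group; cut one bond further out, the change reads 4-chlorophenyl to 4-fluorophenyl. The number is expected to move little, if at all: the step from compound 2 to compound 3 is estimated at a 1.5-fold lower number from compound 2 to compound 3 (0.17 log units; within the scatter), a shift toward a lower number that need not exceed the scatter. Compound 3 is expected to give 17000 nM in this assay, within 8000 nM to 36000 nM.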

Compound 3, half-maximal inhibitory concentration: 20900 nM
The estimate for compound 3 lay 1.2-fold (0.09 log units) below the measured number; the measured number falls inside the stated range.
By their numbers in this assay, from the lowest: compounds 1, 3 and 2 (each within the scatter of the next, the first and the last beyond it).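

In this assay, fluoro in place of chloro, para to a large group, gives a 1.2-fold lower number from compound 2 to compound 3 (0.08 log units; within the scatter), the first single change read directly in the series, and it lies within the scatter. A second single change, chloro in place of hydrogen on an aromatic carbon, gives a 1.8-fold higher number from compound 1 to compound 3 (0.25 log units; within the scatter), also within the scatter, so neither change on its own separates its pair of compounds. Nothing beyond these numbers bears on either step.

The compounds shown carry only chloro or fluoro at this position, so what an amine or a carboxylic acid there would do to the number stays open. Also open, as far as these compounds go, is whether either step would keep its size if the group at the other changed place were different.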